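The compounds below may be only part of what the source reports. "The series", "measured", "known", "first", "only" and "open" are said of these compounds alone.

Among the measured compounds shown here, compound 3 `Cc1ccc(S(=O)(=O)c2n[nH]c3ccc(N4CCN(C)CC4)cc23)cc1` is one of three compounds measured in a functional assay on HeLa cells for antagonist activity at 5-hydroxytryptamine receptor 6 (Homo sapiens); a lower number here means a smaller maximal response, a higher number a larger maximal response. In this assay compound 3 gives 100%. Compound 2 `COc1ccc(S(=O)(=O)c2n[nH]c3ccc(N4CCN(C)CC4)cc23)cc1` gives 100% in this assay, and compound 1 `CN1CCN(c2ccc3[nH]nc(S(=O)(=O)c4ccc(F)cc4)c3c2)CC1` gives 98%. Compound 3 thus stands level with compound 2, the two of them together at the top of the three numbers, with compound 1 within the scatter of both: a number 2 percentage points higher from compound 1 to compound 3 (within the scatter), no change at the digits printed from compound 2 to compound 3 (within the scatter), and also a number 2 percentage points higher from compound 1 to compound 2 (within the scatter).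

Compound 4 `COc1cccc(S(=O)(=O)c2n[nH]c3ccc(N4CCN(C)CC4)cc23)c1` is not yet measured. Its difference from compound 3 is 3-methoxyphenyl in place of 4-methylphenyl on a sulfonyl sulfur. The step bearing most closely on this change also exchanged a methoxy group for a methyl group on the same aromatic carbon, and it showed no change at the digits printed from compound 2 to compound 3 (within the scatter). The two other steps, a number 2 percentage points higher from compound 1 to compound 2 (within the scatter) and a number 2 percentage points higher from compound 1 to compound 3 (within the scatter), likewise stayed within the scatter. Compound 4 is therefore expected to show no change at the digits printed from compound 3 to compound 4 (within the scatter), a step of no size beyond the scatter. The estimate for compound 4 in this assay is 100%, within a range from 90% to 108%.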

Compound 4, largest response reached (reported as Imax), in percent of the reference or control that the assay uses: 100%
The estimate for compound 4 equals the measured number at the digits printed, and the stated range covers the measured number.
By their numbers in this assay, from the lowest: compounds 1, 2, 3 and 4 (each within the scatter of the next).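

In this assay, among the compounds shown here, 3-methoxyphenyl in place of 4-methoxyphenyl on the sulfonyl sulfur gives no change at the digits printed from compound 2 to compound 4 (within the scatter), so the site of the methoxy group on this ring, which the earlier compounds did not vary, leaves the number within the scatter. The comparisons with the other two groups read the same way, with no change at the digits printed from compound 3 to compound 4 (within the scatter) against 4-methylphenyl and a number 2 percentage points higher from compound 1 to compound 4 (within the scatter) against 4-fluorophenyl. No measurement at hand gives a reason for this result.

All four numbers lie within the scatter of one another, so the compounds shown do not reveal what on this ring could shift the maximal response. From the compounds shown here alone, whether an amine or a carboxylic acid on the phenyl ring, or a butoxy chain in place of methoxy, would stay within that scatter remains open.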